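The source may hold more compounds than are shown below. What is called first, only, known or untested is meant among the compounds shown, and "the series" means these compounds.

Three amides have been tested in a functional assay on PANC-1 cells (Homo sapiens) for cytotoxicity, read by WST assay, with a stated time of 24 h; a higher number here means a weaker inhibitor, a lower number a stronger inhibitor: compound 1 `O=C(/C=C/CCCCCCc1ccccc1)N1CCCCC1`, compound 2 `O=C(CCCCCCCCc1ccccc1)N1CCCCC1` and compound 3 `O=C(CCCCCCCc1ccccc1)N1CCCCC1`. Compound 1 gives > 100000 nM, which is a limit of the assay and not a number. Compound 2 gives > 100000 nM, also a limit. Compound 3 gives > 100000 nM, again a limit. Compound 2 therefore stands with the others, and the whole set sits at the limit of > 100000 nM in this assay, at which 3 of the 3 values shown sit.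

Compound 4 `O=C(CCCCCCCCCc1ccccc1)N1CCCCC1` differs from compound 2 in one place: benzyl in place of phenyl on a saturated chain carbon, eight bonds along the chain from a carbonyl carbon. That is benzyl in place of phenyl on a saturated chain carbon, eight bonds along the chain from a carbonyl carbon. Going by the values given here, the one measured step that bears on this is the similar change at the chain end, running the other way: a step that the two limits leave unreadable from compound 2 to compound 3. Its size cannot be read, so no step beyond the scatter is expected in this assay. The expected change is a step that the limit leaves unreadable from compound 2 to compound 4. For compound 4 the estimated value is 120000 nM, with an expected range of 50000 nM to 300000 nM, and the assay will most likely report only a limit again.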

Compound 4, half-maximal inhibitory concentration: > 100000 nM
Compound 4 was reported as a limit; the forecaster's own chance of this, stated with the estimate: 85%; the middle value lies beyond the limit too.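

Compound 2 and compound 4 are both reported as a limit and not as a number, so no step between them can be read: the limit of > 100000 nM in this assay, at which 4 of the 4 values shown sit.

The compounds shown leave open how far each one lies past that limit in this assay, and whether any of these chains gives a readable value.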